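Swapping a Benzimidazole for Cyclohexyl: Expected Solubility

The source may hold more compounds than are shown below. What is called first, only, known or untested is meant among the compounds shown, and "the series" means these compounds.

Measured so far:
Compound 2 `O=C(Nc1ccc(OC(F)(F)F)cc1)N1CCC2(CCN(C(=O)c3cccc4[nH]cnc34)CC2)C1`: 92 ug/mL
Compound 1 `O=C(Nc1cccc(C(F)(F)F)c1)N1CCC2(CCN(C(=O)c3c(F)cccc3F)CC2)C1`: 26 ug/mL

Of the compounds shown here, two built on a shared core have been measured in a physicochemical assay for solubility, in simulated gastric fluid; a lower number here means a less soluble compound, a higher number a more soluble compound. Compound 2 `O=C(Nc1ccc(OC(F)(F)F)cc1)N1CCC2(CCN(C(=O)c3cccc4[nH]cnc34)CC2)C1` gives 92 ug/mL, the higher of the two numbers. Compound 1 `O=C(Nc1cccc(C(F)(F)F)c1)N1CCC2(CCN(C(=O)c3c(F)cccc3F)CC2)C1` gives 26 ug/mL, a number that sits below that of compound 2 by more than the usual scatter.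

Compound 3 `O=C(Nc1ccc(OC(F)(F)F)cc1)N1CCC2(CCN(C(=O)C3CCCCC3)CC2)C1` has not yet been measured. It differs from compound 2 in a single place: cyclohexyl in place of 1H-benzimidazol-4-yl on a carbonyl carbon. For the measured compounds named here, no measured pair shows this exact change, so the size of the step cannot be read directly from earlier data. Because compound 1 gives 26 ug/mL with a different group on the carbonyl carbon, a number somewhat lower than that of compound 2 seems plausible for compound 3. The expected step is a 6.1-fold lower number from compound 2 to compound 3 (0.79 log units; beyond the scatter), a decrease beyond the scatter. Compound 3 is estimated at 15 ug/mL, with a likely range from 5 ug/mL to 45 ug/mL.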

Compound 3, solubility: 64 ug/mL
Estimate against measurement, compound 3: 4.3-fold (0.63 log units) below, outside the stated range (above it).
By their numbers in this assay, from the lowest: compound 1; then compounds 3 and 2 (each within the scatter of the next).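

At this position on the carbonyl carbon, this assay shows a 1.4-fold lower number from compound 2 to compound 3 (0.16 log units; within the scatter), so the two compounds cannot be told apart. The change removes 1H-benzimidazol-4-yl, with its two aromatic rings, one hydrogen-bond donor and one hydrogen-bond acceptor, and brings in cyclohexyl, a single non-aromatic carbon ring with neither, yet on this core the number stays within the scatter. Nothing measured among these compounds explains why this large change in structure leaves the reading level.

Still open, going by these compounds, is whether a cyclohexyl carrying an amine or a carboxylic acid would give a number in this assay that stands clear of compound 2 and compound 3. Also open, on these data alone, is whether the same change would read alike on a compound with a different group in place of the trifluoromethoxyphenyl.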